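Removing a Chlorine from a Urea-Linked Benzamide

The source may hold more compounds than are shown below. What is called first, only, known or untested is meant among the compounds shown, and "the series" means these compounds.

Compound 1 `Nc1ccccc1NC(=O)c1ccc(NC(=O)NCc2ccc(Cl)nc2)cc1` carries a urea that links its shared core to a (6-chloropyridin-3-yl)methyl group. In an assay on isolated protein for inhibition of Nicotinamide phosphoribosyltransferase (Homo sapiens), read by fluorescence, with stated times of 5 min and 15 min (on this read-out lower numbers stand for stronger inhibition and higher numbers for weaker inhibition), compound 1 gives only a limit, > 2000 nM, and not a number. A second compound, compound 2 `Nc1ccccc1NC(=O)c1ccc(NC(=S)NCc2cccc(F)c2)cc1`, joins a thiourea to a fluorophenyl group in place of the pyridine. In this assay compound 2 likewise gives only a limit, > 2000 nM. Compound 1 thus stands at the limit of > 2000 nM in this assay, at which 2 of the 2 values shown sit, and nothing in these measurements separates it from compound 2.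

Compound 3 `Nc1ccccc1NC(=O)c1ccc(NC(=O)NCc2cccnc2)cc1` differs from compound 1 by hydrogen in place of chloro on an aromatic carbon. Within the data shown here, no measured pair shows what hydrogen in place of chloro on an aromatic carbon does in this assay, so the outlook rests on compound 1 alone, whose result > 2000 nM shows no measurable inhibition. Removing a single chlorine is a small change, and the step from compound 1 to compound 3 is expected to stay within the scatter, a step that the limit leaves unreadable from compound 1 to compound 3, with no clear direction. Compound 3 is therefore expected to give about 6000 nM, most likely again only a limit, in a range from 1500 nM to 40000 nM.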

Compound 3, half-maximal inhibitory concentration: 550 nM
The estimate for compound 3 lay 11-fold (1.04 log units) above the measured number, and the stated range ends above it.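

In this assay, replacing the chloro group of the 6-chloropyridin-3-yl ring with hydrogen gives an at least 3.6-fold lower number from compound 1 to compound 3 (0.56 log units; beyond the scatter). This shows that the aromatic carbon next to the ring nitrogen is not a place where a change goes unnoticed: in this one pair, a single chlorine separates a compound with a measurable number from one without. Compound 3 is also the only compound shown with a number, and the others remain at a limit: the limit of > 2000 nM in this assay, at which 2 of the 3 values shown sit.

Compound 1 has only a limit, so the full size of the step cannot be read, and these compounds give no reason for it. As far as these compounds go, it also remains open whether a fluorine, a methyl group or an amine at this same position would keep the stronger inhibition of compound 3 or lose it, and whether removing the chlorine would have the same effect on a different core.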